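Moving the methoxy group on the triazole-bound phenyl ring

A few compounds are considered here, and "the series" means these few. Any claim that something is new, unique, unknown or untested is made for them only; others in the source may bear on it.

The measured compounds:
compound 1, `COc1ccccc1-n1c(Nc2nc(-c3ccc(Cl)cc3)cs2)n[nH]c1=S`, 100 mg/kg in a functional assay on the whole organism (strain Swiss albino) for inhibition, with Mus musculus as the target, with a stated time of 4 h; a higher number here means that more compound is needed for the effect, a lower number that less compound is needed
compound 2, `COc1ccccc1-n1c(Nc2nc(-c3ccccc3)cs2)n[nH]c1=S`, 300 mg/kg
compound 3, `COc1ccccc1-n1c(Nc2nc(-c3ccc([N+](=O)[O-])cc3)cs2)n[nH]c1=S`, 100 mg/kg

Compound 2 stands at the highest of the three numbers, so the most compound is needed for the effect in its case. Its nearest neighbour is compound 1, with a 3.0-fold higher number from compound 1 to compound 2 (0.48 log units; beyond the scatter), and the gap to compound 3 is the same size, a 3.0-fold lower number from compound 2 to compound 3 (0.48 log units; beyond the scatter). Compound 1 and compound 3 sit within the scatter of each other, no change at the digits printed from compound 1 to compound 3 (within the scatter).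

Compound 4, `COc1ccc(-n2c(Nc3nc(-c4ccccc4)cs3)n[nH]c2=S)cc1`, has not been measured. It differs from compound 2 in one place: 4-methoxyphenyl in place of 2-methoxyphenyl on an aromatic nitrogen. The shared core and the phenyl ring on the thiazole are unchanged.

Among the compounds with values here, none of the measured steps touches the methoxyphenyl group; all three vary the substituent on the other aromatic ring, and each of the two steps that lie beyond the scatter is only modest. The data therefore give no direct guide to moving the methoxy group, and the plain expectation is that the step of no change at the digits printed from compound 2 to compound 4 (within the scatter) stays within the scatter. Compound 4 is accordingly estimated at 300 mg/kg, between 100 mg/kg and 600 mg/kg.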

Compound 4, minimum effective dose: 100 mg/kg
Compound 4: middle estimate off by 3.0-fold (0.48 log units), on the high side, within the range that was stated.
By their numbers in this assay, from the lowest: compounds 1, 3 and 4 (each within the scatter of the next); then compound 2.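

The methoxyphenyl group on the aromatic nitrogen is not a silent part of the molecule: in this assay, moving the methoxy group alone gives a 3.0-fold lower number from compound 2 to compound 4 (0.48 log units; beyond the scatter). The earlier compounds shown here varied only the other aromatic ring, and they showed the number falling from compound 2 with one change there, a 3.0-fold lower number from compound 2 to compound 3 (0.48 log units; beyond the scatter); the new step shows that it can also fall through a change at the other end of the molecule, with no change in the heavy atoms, hydrogen-bond donors or acceptors counted for the group. No measurement shown here bears on the reason for this step.

As far as these compounds go, it remains open whether 4-methoxyphenyl on the aromatic nitrogen and a nitro or chloro group on the other aromatic ring would lower the number further when combined, since each change has been read only on its own against a different partner. Also open, from the compounds shown here alone, is whether a 4-ethoxyphenyl or 4-hydroxyphenyl group in the same place would hold the number of compound 4 or move it.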